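The compounds below may be only part of what the source reports. "The series", "measured", "known", "first", "only" and "open" are said of these compounds alone.

Measured so far in a functional assay on MIA PaCa-2 cells (Homo sapiens) for antiproliferative activity, read by sulforhodamine B assay, with a stated time of 48 h; a lower number here means a stronger inhibitor, a higher number a weaker inhibitor:
compound 1, `COc1cc(C(=O)/C=C\Nc2ccc(-c3nc4cc(OC)c(OC)c(OC)c4s3)cc2)c(Br)c(OC)c1OC`, gives 23200 nM;
compound 2, `COc1cc(C(=O)/C=C\Nc2ccc(-c3nc4cc(OC)c(OC)c(OC)c4s3)cc2C)cc(OC)c1OC`, gives 22800 nM;
compound 3, `COc1ccc(C(=O)/C=C\Nc2ccc(-c3nc4cc(OC)c(OC)c(OC)c4s3)cc2)cc1[N+](=O)[O-]`, gives 15900 nM.

Compound 3 has the lowest of the three numbers, yet its gaps to compound 2 and to compound 1 both lie within the scatter, so the three sit together as weak inhibitors with no ranking among them. Compound 4, `COc1ccc(C(=O)/C=C\Nc2ccc(-c3nc4cc(OC)c(OC)c(OC)c4s3)cc2)cc1O`, differs from compound 3 by one change: hydroxy in place of nitro on an aromatic carbon. Within the data shown here, no measured pair here shows what this change does, so the expectation rests on the shared core alone. The step is expected to be small, a slight decrease or none beyond the scatter, as a 1.3-fold lower number from compound 3 to compound 4 (0.12 log units; within the scatter). Compound 4 is therefore estimated at 12000 nM, with a range from 3000 nM to 40000 nM in this assay.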

Compound 4, half-maximal inhibitory concentration: 32800 nM
Estimate against measurement, compound 4: 2.7-fold (0.44 log units) below; measured number inside the range.
By their numbers in this assay, from the lowest: compounds 3, 2, 1 and 4 (each within the scatter of the next, the first and the last beyond it).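

In this assay, hydroxy in place of nitro on this aromatic carbon, ortho to a methoxy group, gives a 2.1-fold higher number from compound 3 to compound 4 (0.31 log units; beyond the scatter). Among these compounds, this is the first step here that passes the scatter, so the group at this place does move the number, and of this pair the nitro compound is the stronger inhibitor. The step is modest, however, and both compounds remain weak. As far as these compounds go, whether an amine or a carboxylic acid at this place would give a lower number stays open. Nothing available explains why the number rises.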